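The source may report more compounds than this note shows. Statements on the series, on what has been measured and on what is new or still open speak of the compounds shown alone.

In a physicochemical assay for solubility, at pH 7 (a lower number here means a less soluble compound, a higher number a more soluble compound), compound 1 `CCOC(=O)c1ccccc1C(=O)N1C[C@H](Oc2cc(C#N)ccn2)CC[C@H]1C` gives 121000 nM and compound 2 `CC(C)OC(=O)c1ccccc1C(=O)N1C[C@H](Oc2cc(C#N)ccn2)CC[C@H]1C` gives 115000 nM, so these two stand level within the scatter. Compound 3 `C[C@@H]1CC[C@@H](Oc2cc(C#N)ccn2)CN1C(=O)c1ccccc1CC(F)(F)F` comes from compound 2 through one structural change: 2,2,2-trifluoroethyl in place of isopropoxycarbonyl on an aromatic carbon. Going by the values given here, only one measured step bears on this, a 1.1-fold lower number from compound 1 to compound 2 (0.02 log units; within the scatter). That step adds a methyl within the chain of the group that now leaves, whereas here the whole group is replaced. It therefore shows that the smaller edit left the number within the scatter, but it does not measure a swap of this kind. Among the compounds with values here, with no direct precedent, a moderate fall in this assay is expected, and this is a cautious judgement. The expected change is a 1.6-fold lower number from compound 2 to compound 3 (0.22 log units; within the scatter), and it remains uncertain. For compound 3 the estimated value is 70000 nM, with an expected range of 25000 nM to 160000 nM.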

Compound 3, solubility: 95000 nM
The estimate for compound 3 lay 1.4-fold (0.13 log units) below the measured number; low and high end bracket the measured number.
By their numbers in this assay, from the lowest: compounds 3, 2 and 1 (each within the scatter of the next).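

Up to this point, the only measured change at this site was a small one within the ester chain. Compound 3 replaces the entire group on the aromatic carbon, and this assay gives a 1.2-fold lower number from compound 2 to compound 3 (0.08 log units; within the scatter) for the swap of isopropoxycarbonyl for 2,2,2-trifluoroethyl, and a 1.3-fold lower number from compound 1 to compound 3 (0.11 log units; within the scatter) for the matching swap of ethoxycarbonyl, so these three compounds stand level even though the leaving groups carry hydrogen-bond acceptors and the entering group carries none. No measurement here offers an explanation for this.

As far as these compounds go, whether the level reading would hold for a different kind of group on this aromatic carbon, such as an amine or a carboxylic acid, remains open. So does the question of whether a longer fluorinated chain in the same place would give a similar number.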